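The compounds below may be only part of what the source reports. "The series", "measured", "known", "first", "only" and "open" are said of these compounds alone.

Measured so far in a physicochemical assay for solubility, read by HPLC, in phosphate buffer, measured as kinetic solubility, at pH 7.4; on this read-out higher numbers stand for higher solubility and lower numbers for lower solubility
- compound 1 `CC(=O)c1cc(-c2ccc(S(N)(=O)=O)cc2)n(-c2ccc(Cl)cc2)n1` gives 86800 nM
- compound 2 `NS(=O)(=O)c1ccc(-c2cc(C(=O)CC3CCCC3)nn2-c2ccc(Cl)cc2)cc1` gives 2600 nM
- compound 3 `NS(=O)(=O)c1ccc(-c2cc(C(=O)N3CCCCC3)nn2-c2ccc(Cl)cc2)cc1` gives 65900 nM

Compound 3 stands with compound 1 at the upper end of the three numbers, the pair inseparable within the scatter, while compound 2 lies far lower.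

Compound 4 `CN(C(=O)c1cc(-c2ccc(S(N)(=O)=O)cc2)n(-c2ccc(Cl)cc2)n1)C1CC1` keeps the core of compound 3 and changes one group: cyclopropyl(methyl)amino in place of piperidin-1-yl on a carbonyl carbon. Among the compounds with values here, no measured step exchanges one amino group for another on that carbon. Piperidin-1-yl in place of methyl there gave a 1.3-fold lower number from compound 1 to compound 3 (0.12 log units; within the scatter) and is the nearest precedent, a small one. Piperidin-1-yl in place of cyclopentylmethyl gave a 25-fold higher number from compound 2 to compound 3 (1.40 log units; beyond the scatter) and cyclopentyl in place of hydrogen on the chain gave a 33-fold lower number from compound 1 to compound 2 (1.52 log units; beyond the scatter) as the second large step. Both large steps involve the cyclopentyl-bearing chain of compound 2, which compound 4 does not carry.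

No step beyond the scatter is therefore expected in this assay and no direction is claimed. The estimate reads a 1.1-fold higher number from compound 3 to compound 4 (0.03 log units; within the scatter) as the expected move. The expected value for compound 4 is 70000 nM with an estimated range from 25000 nM to 100000 nM for this measurement.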

Compound 4, solubility: 99600 nM
Compound 4: middle estimate off by 1.4-fold (0.15 log units), on the low side; low and high end bracket the measured number.
By their numbers in this assay, from the lowest: compound 2; then compounds 3, 1 and 4 (each within the scatter of the next).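

In this assay, within the data shown here, the first exchange of one amino group for another on the carbonyl carbon, cyclopropyl(methyl)amino in place of piperidin-1-yl, gives a 1.5-fold higher number from compound 3 to compound 4 (0.18 log units; within the scatter), so replacing the six-membered ring with a three-membered ring and a methyl leaves the two amino-bearing compounds inseparable. Among these compounds, the same amino group in place of methyl gives a 1.1-fold higher number from compound 1 to compound 4 (0.06 log units; within the scatter), while in place of cyclopentylmethyl it gives a 38-fold higher number from compound 2 to compound 4 (1.58 log units; beyond the scatter), which leaves compound 2 as the only one of the four compounds set apart from the others. No measurement at hand bears on why the numbers fall this way.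

Open, as far as these compounds go, is whether other amino groups on that carbonyl carbon, such as morpholin-4-yl, dimethylamino or an unsubstituted amino group, stay with compound 1, compound 3 and compound 4. Also open, from the compounds shown here alone, is whether a plain longer chain such as n-butyl, or a cyclopentyl directly on the carbonyl carbon, moves the number as far as the cyclopentylmethyl of compound 2 does.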